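The source may report more compounds than this note shows. Statements on the series, on what has been measured and on what is new or still open speak of the compounds shown alone.

In a functional assay on NCI-H460 cells (Homo sapiens) for inhibition, read by MTT assay, with a stated time of 24 h, tested at 10 ug/mL (a lower number here means less inhibition of growth, a higher number more inhibition of growth at the concentration tested), compound 1 (`O=C(CCCCC1CCSS1)Nc1cccc2ccccc12`) is reported as "not active" (no number reported). No number comes with that verdict, so it offers no figure from which to measure a step. Compound 4 (`O=C(CCCCC(S)CCS)Nc1cccc2ccccc12`) keeps the rest of compound 1 and differs only in its sulfur-bearing group: a group of 5 heavy atoms (3 carbon, 2 sulfur; no ring) in place of a group of 5 heavy atoms (3 carbon, 2 sulfur; one five-membered non-aromatic ring with 2 hetero atoms), on a saturated chain carbon, four bonds along the chain from a carbonyl carbon. The five-membered ring is gone, and an open 1,3-disulfanylpropyl group stands in its place.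

Two measured compounds already carry this open group. Compound 2 (`O=C(CCCCC(S)CCS)Nc1cccc(C(F)(F)F)c1`) gives 11.4%, and compound 3 (`Cc1cccc(NC(=O)CCCCC(S)CCS)c1`) gives 7.67%. Going by the values given here, the one measured step between them is a number 3.7 percentage points lower from compound 2 to compound 3 (within the scatter). It is small, and it concerns a group on an aromatic carbon, not the sulfur-bearing group, so it bears on the change at hand only indirectly. It does suggest that, among these two open compounds, swapping that aromatic substituent left the reading within the scatter.

Among the compounds with values here, no measured pair shows directly what opening the ring does. The best guide is therefore the level of the two open compounds, which points to a modest move upward from the inactive compound 1, to weak inhibition rather than strong. The estimated value for compound 4 is 11%, with an expected range from 2% to 28%.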

Compound 4, percent growth inhibition at one concentration: "not active" (no number reported)
Compound 4: no number reported; no gap can be computed for the estimate.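

In this assay compound 1 reads "not active" (no number reported) and compound 4 reads "not active" (no number reported) - with no figure on either side, no step can be read between them. What the compounds shown leave open is whether replacing the five-membered ring with the open 1,3-disulfanylpropyl group shifts growth inhibition by any amount. No measurement shown offers an explanation for this result.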